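Oxygen to Sulfur in a Five-Membered Ring on the Core

A few compounds are considered here, and "the series" means these few. Any claim that something is new, unique, unknown or untested is made for them only; others in the source may bear on it.

Compound 1, `Nc1nc(Cl)c(-c2ccco2)c(N[C@@H]2C[C@H](CO)[C@@H](O)[C@H]2O)n1`: > 25000 nM
Compound 2, `Nc1nc(Cl)c(-c2ncco2)c(N[C@@H]2C[C@H](CO)[C@@H](O)[C@H]2O)n1`: > 25000 nM

In an ADME assay on cells (Homo sapiens) for cytotoxicity, read by polymerase chain reaction, with a stated time of 3 days (a higher number here means that more compound is tolerated, a lower number that less compound is tolerated), compound 1 gives > 25000 nM, which is a limit of the measurement rather than a number. Compound 2 gives > 25000 nM in this assay, again a limit. Both readings sit at the limit of > 25000 nM in this assay, at which 2 of the 2 values shown sit, so the step that the two limits leave unreadable from compound 1 to compound 2 has no readable size: all that can be said is that neither compound showed measurable toxicity up to the highest concentration tested.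

Compound 3, `Nc1nc(Cl)c(-c2nccs2)c(N[C@@H]2C[C@H](CO)[C@@H](O)[C@H]2O)n1`, has not yet been measured. It differs from compound 2 by 1,3-thiazol-2-yl in place of 1,3-oxazol-2-yl on an aromatic carbon. Going by the values given here, the only measured step that bears on a change in this five-membered ring is a step that the two limits leave unreadable from compound 1 to compound 2, and it gives no size. With both compounds tolerated up to the limit, the expectation for compound 3 is that it too will be tolerated, and the expected step that the limit leaves unreadable from compound 2 to compound 3 is none beyond the scatter. Compound 3 is estimated at 30000 nM in this assay, with a range from 10000 nM to 100000 nM.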

Compound 3, half-maximal cytotoxic concentration: > 25000 nM
Compound 3: only a limit was reported (the forecaster's own chance of this, stated with the estimate: 80%); the middle value is on the limit's open side.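

In this assay compound 3 gives > 25000 nM, which is a limit and not a number. No step from compound 1 or compound 2 to compound 3 can be read, because all the readings share one limit: the limit of > 25000 nM in this assay, at which 3 of the 3 values shown sit.

The compounds shown leave open whether furan-2-yl, 1,3-oxazol-2-yl and 1,3-thiazol-2-yl differ at all in how much compound is tolerated.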